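This account rests on a few compounds, and the source may have more. Where it says the series, first, only, none or still open, it means among the compounds named here.

Measured compounds in a functional assay on HT-29 cells (Homo sapiens) for cytotoxicity, read by MTT assay, with a stated time of 72 h; on this read-out higher numbers stand for weaker inhibition and lower numbers for stronger inhibition:
- compound 1 `COc1ccc(C(=O)c2cc(OC)c(OC)c(OC)c2)cc1NC(=O)/C=C/c1cc(OC)c(OC)c(OC)c1`: 3100 nM
- compound 2 `C#CCOc1cccc(/C=C/C(=O)Nc2cc(C(=O)c3cc(OC)c(OC)c(OC)c3)ccc2OC)c1`: 7400 nM
- compound 3 `COc1cc(C(=O)c2cc(OC)c(OC)c(OC)c2)cc(NC(=O)/C=C/c2cc(OC)c(OC)c(OC)c2)c1OC`: 3100 nM

Compound 3 stands level with compound 1 at the digits printed, and these two share the lowest number of the three; compound 2 sits furthest away, as a 2.4-fold higher number from compound 1 to compound 2 (0.38 log units; beyond the scatter) shows. The step from compound 1 to compound 3 is only an added methoxy on an aromatic carbon, and no change at the digits printed from compound 1 to compound 3 (within the scatter) records no shift in this assay.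

Compound 4 `COc1cc(C(=O)c2cc(OC)c(OC)c(OC)c2)cc(NC(=O)/C=C/c2ccc(F)cc2)c1OC` differs from compound 3 in one place: 4-fluorophenyl in place of 3,4,5-trimethoxyphenyl on a double-bonded chain carbon bound to a double-bonded chain carbon. Within the data shown here, the only measured step that bears on this exchange is the one from compound 1 to compound 2, where a different group replaced the same 3,4,5-trimethoxyphenyl at the same chain position and gave a 2.4-fold higher number from compound 1 to compound 2 (0.38 log units; beyond the scatter), a modest weakening. A similar modest step is therefore expected, in the weaker direction, giving a 2.3-fold higher number from compound 3 to compound 4 (0.35 log units; beyond the scatter). Compound 4 is estimated at 7000 nM, with a plausible range from 2500 nM to 20000 nM.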

Compound 4, half-maximal inhibitory concentration: 1800 nM
Compound 4: the middle estimate sits 3.9-fold (0.59 log units) above what was measured, outside the stated range (below it).
By their numbers in this assay, from the lowest: compounds 4, 1 and 3 (each within the scatter of the next); then compound 2.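

At this chain position the 3,4,5-trimethoxyphenyl group can give way to 4-fluorophenyl, with fewer heavy atoms and no hydrogen-bond acceptors in place of 3, without a change that stands out in this assay: the result is a 1.7-fold lower number from compound 3 to compound 4 (0.24 log units; within the scatter), so compound 3 and compound 4 cannot be told apart here. The earlier exchange at this place, a 2.4-fold higher number from compound 1 to compound 2 (0.38 log units; beyond the scatter), had suggested a cost to losing the trimethoxyphenyl group, but compound 4 shows that this loss does not bring a weaker number with every replacement. Nothing measured here explains why these two exchanges turned out differently.

From the compounds shown here alone, whether the fluorine itself matters stays open, as a plain phenyl group at this place would be needed to test it. How a 4-aminophenyl or 4-carboxyphenyl group would behave on this chain carbon is also unknown.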